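A few compounds are considered here, and "the series" means these few. Any claim that something is new, unique, unknown or untested is made for them only; others in the source may bear on it.

Three compounds share a core that carries a nitrile-bearing pyrrolidine amide, and they differ only in the group attached to the second carbonyl carbon. Compound 1 `N#C[C@@H]1CCCN1C(=O)[C@@H]1C[C@H](C(=O)N2CCOCC2)CN1` gives 44% in an assay on the whole organism (plasma, strain Sprague-Dawley) for inhibition of Dipeptidyl peptidase 4 (Rattus norvegicus), with a stated time of 10 h, at a dose of 1 mg/kg by the oral route; a lower number here means less inhibition, a higher number more inhibition at the dose given (going by the name of the read-out). Compound 2 `CCCNC(=O)[C@@H]1CN[C@H](C(=O)N2CCC[C@H]2C#N)C1` gives 21% in this assay, and compound 3 `N#C[C@@H]1CCCN1C(=O)[C@@H]1C[C@H](C(=O)N2CCCCC2)CN1` gives 50% in this assay. Compound 3 carries the highest of the three numbers, though its step of a number 6 percentage points higher from compound 1 to compound 3 (within the scatter) keeps it within the scatter of compound 1, while the step of a number 29 percentage points higher from compound 2 to compound 3 (beyond the scatter) separates it clearly from compound 2.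

Compound 4 `CCNC(=O)[C@@H]1CN[C@H](C(=O)N2CCC[C@H]2C#N)C1` is the next compound to be measured. Relative to compound 3 it differs as follows: ethylamino in place of piperidin-1-yl on a carbonyl carbon. For the measured compounds named here, two measured steps bear on this change. Replacing a cyclic amine on that carbonyl carbon with an open-chain alkylamino group gave the step of a number 23 percentage points lower from compound 1 to compound 2 (beyond the scatter), and the reverse swap gave a number 29 percentage points higher from compound 2 to compound 3 (beyond the scatter). Since compound 4 carries an open-chain ethylamino group in the same place, the expected step of a number 28 percentage points lower from compound 3 to compound 4 (beyond the scatter) is a decrease of modest size, comparable to those two steps. Compound 4 is therefore estimated to give 22% in this assay, with a likely range from 8% to 38%.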

Compound 4, a percentage reported as inhibition, in the whole organism at one dose (the size of the read-out at that dose, not a potency): 19%
For compound 4 the middle estimate is 3 percentage points above the measured one; measured number inside the range.
By their numbers in this assay, from the lowest: compounds 4 and 2 (each within the scatter of the next); then compounds 1 and 3 (each within the scatter of the next).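

In this assay, shortening the open chain from propylamino to ethylamino on the carbonyl carbon gives a number 2 percentage points lower from compound 2 to compound 4 (within the scatter) and so leaves the two open-chain compounds level. The low numbers are thus not tied to one chain length, and the gap to the cyclic amines holds for a second open chain, with ethylamino giving a number 31 percentage points lower from compound 3 to compound 4 (beyond the scatter) against piperidin-1-yl and a number 25 percentage points lower from compound 1 to compound 4 (beyond the scatter) against morpholin-4-yl. No measurement at hand explains this gap, and ethylamino differs from piperidin-1-yl at once in lacking a ring, in carrying a hydrogen-bond donor and in having fewer heavy atoms, so these features cannot be told apart here.

From the compounds shown here alone, what remains open is whether a dimethylamino group, which has an open form but no amide hydrogen, would stand with the cyclic amines or with the two open-chain compounds. Going by these compounds, it is also open whether a longer chain such as hexylamino would stay level with ethylamino and propylamino, and whether a smaller ring such as pyrrolidin-1-yl would keep the number seen with piperidin-1-yl.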